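The source may report more compounds than this note shows. Statements on the series, on what has been measured and on what is new or still open speak of the compounds shown alone.

Compound 1 `CC(CCc1cccc(OCc2ccc3ccccc3n2)c1)Cc1nnn[nH]1`: 17 nM
Compound 2 `O=C(O)CCC(Cc1ccc(OCc2ccc3ccccc3n2)cc1)c1ccccc1`: 31 nM
Compound 3 `CC(CCCc1nnn[nH]1)c1cccc(OCc2ccc3ccccc3n2)c1`: 31 nM

All three numbers come from an assay on membranes from lung (Cavia porcellus) for binding affinity to cysteinyl leukotriene receptor (Homo sapiens); on this read-out lower numbers stand for stronger inhibition and higher numbers for weaker inhibition. Compound 1 gives the lowest number of the three, but compound 2 and compound 3 each lie within the scatter of it, so no ordering among them is claimed. Compound 4 `CCCC(CCC(=O)O)Cc1cccc(OCc2ccc3ccccc3n2)c1` is not yet measured. The change from compound 1 is 1-(2-carboxyethyl)butyl in place of 2-((1H-tetrazol-5-yl)methyl)propyl on a saturated chain carbon bound to an aromatic carbon. Among the compounds with values here, no step between measured compounds isolates this exchange; the only guide is compound 2, which also carries a carboxylic acid and gives 31 nM in this assay. The expected step is a 1.8-fold higher number from compound 1 to compound 4 (0.25 log units; within the scatter), small and toward a somewhat higher number, probably not beyond the scatter. Compound 4 is estimated at 30 nM, with a range of 10 nM to 100 nM.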

Compound 4, inhibition constant: 50 nM
Estimate against measurement, compound 4: 1.7-fold (0.22 log units) below; the measured number falls inside the stated range.
By their numbers in this assay, from the lowest: compounds 1, 2, 3 and 4 (each within the scatter of the next, the first and the last beyond it).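

In this assay, within the data shown here, 1-(2-carboxyethyl)butyl in place of 2-((1H-tetrazol-5-yl)methyl)propyl on a saturated chain carbon bound to an aromatic carbon gives a 2.9-fold higher number from compound 1 to compound 4 (0.47 log units; beyond the scatter) and is the only step so far that isolates a change at this position. The two side chains are therefore not interchangeable here, although the step is modest. No measurement at hand accounts for this step.

As far as these compounds go, the exchange alters the acid-bearing group and the chain together, so the contribution of each remains open. A primary amide in place of the carboxylic acid, or a 1H-tetrazol-5-yl group on the butyl chain, would bear on this.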